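The compounds below may be only part of what the source reports. "The series", "measured", "known", "first", "only" and "open" are said of these compounds alone.

Measured so far:
compound 1 `C[C@@]12CCCC[C@H]1CC=C(O)C2=O` — > 2000000 nM
compound 2 `CC1(C)[C@@H]2CC3=NCC(=O)O[C@@]3(C)[C@H]1C2` — > 900000 nM

In an ADME assay on NIH3T3 cells (Mus musculus) for antiproliferative activity, read by sulforhodamine B assay, with a stated time of 48 h (on this read-out lower numbers stand for stronger inhibition and higher numbers for weaker inhibition), compound 1 gives only a limit, > 2000000 nM, and no number. In this assay compound 2 likewise gives only a limit, > 900000 nM, with no number behind it. Both measured compounds therefore sit at the edge of what this assay reports; compound 2 stands nowhere on a scale, because its value is a limit (the limit of > 900000 nM in this assay, at which 1 of the 2 values shown sits), and the other value shown is a limit too (the limit of > 2000000 nM in this assay, at which 1 of the 2 values shown sits).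

Compound 3 `CC1(C)[C@H]2CC3=NCC(=O)O[C@]3(C)[C@@H]1C2` is the mirror image of compound 2: the two compounds have the same atoms and bonds and differ only in configuration as drawn: 3 of 3 stereo elements differ (all stereocentres are inverted: mirror images); a stereocentre at a saturated ring carbon is drawn S in compound 2 and R in compound 3; a stereocentre at a saturated ring carbon is drawn S in compound 2 and R in compound 3; a stereocentre at a saturated ring carbon is drawn S in compound 2 and R in compound 3. Among the measured compounds shown here, no step between measured compounds is available to gauge such a change. With compound 2 giving only a limit, the expectation is that the step from compound 2 to compound 3 is none beyond the scatter, so that the estimated step is a step that the limit leaves unreadable from compound 2 to compound 3. Compound 3 is therefore expected to give about 1500000 nM in this assay, within 500000 nM to 5000000 nM, most likely again reported only as a limit.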

Compound 3, half-maximal inhibitory concentration: > 2000000 nM
Compound 3: a limit, no number; the forecaster's own chance of this, stated with the estimate: 85%; middle value at least 1.3-fold (0.12 log units) from the limit.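

In this assay, among the compounds shown here, compound 3 gives only a limit, > 2000000 nM, and compound 2 also gives only a limit, so no step between compound 2 and compound 3 can be read. The compounds shown leave open whether these mirror images differ at all in antiproliferative activity.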